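Swapping the chain-end imidazole for a dihydroxyphenoxy group

The source may hold more compounds than are shown below. What is called first, only, known or untested is meant among the compounds shown, and "the series" means these compounds.

Measured compounds:
- compound 1, `COC1=C(OC)C(=O)C(CCCCCCCCCCN(Cc2ccccc2)Cc2ccccc2)=C(C)C1=O`: 33000 nM
- compound 2, `COC1=C(OC)C(=O)C(CCCCCCCCCCn2ccnc2)=C(C)C1=O`: 3000 nM
- compound 3, `COC1=C(OC)C(=O)C(CCCCCO)=C(C)C1=O`: 13000 nM

All three share the same quinone core and differ in the side chain. In a functional assay on HL-60 cells (Homo sapiens) for antiproliferative activity, read by MTT assay, with a stated time of 48 h (on this read-out lower numbers stand for stronger inhibition and higher numbers for weaker inhibition), compound 2 gives the lowest number of the three, and its gaps to compound 3 and to compound 1 both lie beyond the scatter, so on these numbers compound 2 is the most potent of the set, with compound 3 nearest and compound 1 furthest away.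

The next compound, compound 4, `COC1=C(OC)C(=O)C(CCCCCCCCCCOc2cc(O)cc(O)c2)=C(C)C1=O`, keeps the core and the long chain of compound 2 but changes the group at the chain end: 3,5-dihydroxyphenoxy in place of 1H-imidazol-1-yl on a saturated chain carbon, ten or more bonds along the chain from a double-bonded ring carbon. Within the data shown here, no measured pair in this set isolates this kind of change, so the direction of the step has to be judged from the spread of the three values alone. The groups tried so far at the far end of the chain all land at higher numbers than the imidazole of compound 2, which suggests a moderate rise in the number. Compound 4 is therefore expected to be a somewhat weaker inhibitor, with the step of a 2.7-fold higher number from compound 2 to compound 4 (0.43 log units; beyond the scatter) going upward but by less than the distance to compound 1. Compound 4 is estimated to give about 8000 nM, in a range from 2500 nM to 25000 nM.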

Compound 4, half-maximal inhibitory concentration: 16000 nM
The estimate for compound 4 lay 2.0-fold (0.30 log units) below the measured number; measured number inside the range.
By their numbers in this assay, from the lowest: compound 2; then compounds 3 and 4 (each within the scatter of the next); then compound 1.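

Among these compounds, this is the first pair in the set that differs in one place only, so it gives a direct reading of the chain end: in this assay, 3,5-dihydroxyphenoxy in place of 1H-imidazol-1-yl gives a 5.3-fold higher number from compound 2 to compound 4 (0.73 log units; beyond the scatter), a modest step beyond the scatter. The entering group has more heavy atoms and brings hydrogen-bond donors where the imidazole has none, yet the number rises, so at this place on the long chain these additions bring no gain on this read-out. Nothing measured here explains the step, so its cause remains unknown.

This single pair cannot separate the effect of losing the imidazole from the effect of adding the two hydroxyl groups, and a plain phenoxy end would be the direct test of the hydroxyl groups. It also leaves open where other chain ends, such as a carboxylic acid or a pyridine ring, would fall relative to compound 2 and compound 4, and whether the same swap gives a similar step on a shorter chain.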